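Methoxy in place of methyl on compound 3

The source may hold more compounds than are shown below. What is called first, only, known or untested is meant among the compounds shown, and "the series" means these compounds.

In an ADME assay on liver (Mus musculus) for metabolic stability, read by LC-MS, using microsomes and NADPH (on this read-out higher numbers stand for a more stable compound and lower numbers for a less stable compound), the measured compounds read as follows
Compound 1 `Cc1cc(CN(CC2CC2)C(CC(=O)O)c2ccc(Cl)cc2)ccc1OCCN1C(=O)CCC1=O` gives 83%
Compound 2 `CCCN(Cc1ccc(OCCn2c(=O)ccn(C)c2=O)c(C)c1)C(CC(=O)O)c1ccc(Cl)cc1` gives 23%
Compound 3 `Cc1cc(CN(CC2CC2)C(CC(=O)O)c2ccc(Cl)cc2)ccc1OCCn1c(=O)ccn(C)c1=O` gives 24%

The standing of compound 3 is set by two steps (a number 59 percentage points lower from compound 1 to compound 3 (beyond the scatter)) and (a number 1 percentage points higher from compound 2 to compound 3 (within the scatter)). The unmeasured compound 4 `COc1cc(CN(CC2CC2)C(CC(=O)O)c2ccc(Cl)cc2)ccc1OCCn1c(=O)ccn(C)c1=O` differs from compound 3 by methoxy in place of methyl on an aromatic carbon. Neither measured step touches that aromatic carbon, so neither gives a size for this change, and the data offer no direction for it. A change beyond the scatter is therefore not expected, and the expected step (a number 2 percentage points lower from compound 3 to compound 4 (within the scatter)) is small. Compound 4 is estimated at 22% (expected range 8% to 40%).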

Compound 4, percent of the compound remaining: 42%
The estimate for compound 4 lay 20 percentage points below the measured number; measured number above the stated range.
By their numbers in this assay, from the lowest: compounds 2 and 3 (each within the scatter of the next); then compound 4; then compound 1.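

In this assay, within the data shown here, the aromatic carbon ortho to a large group and meta to a large group proves responsive, a place no earlier step had touched: methoxy in place of methyl gives a number 18 percentage points higher from compound 3 to compound 4 (beyond the scatter). The change on the amine side, by contrast, gave only a number 1 percentage points higher from compound 2 to compound 3 (within the scatter). Nothing measured here accounts for the rise. The compounds shown leave open whether methoxy acts the same way alongside the end group of compound 1. They also leave open how ethoxy or a fluorine atom would read on this aromatic carbon.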